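The source may report more compounds than this note shows. Statements on the series, on what has been measured and on what is new or still open speak of the compounds shown alone.

Measured compounds:
- Compound 1, `Brc1cncc(N2CC[C@H]3CN[C@H]3C2)c1`, gives 76 nM.
- Compound 2, `N/C(=N/O)c1cncc(N2CC[C@@H]3CN[C@@H]3C2)c1`, gives 5700 nM.
- Compound 3, `COc1cc(N2C[C@@H]3CCNC[C@@H]32)cnc1Br`, gives 2980 nM.

All three values come from a functional assay on HEK293 cells for agonist activity at Neuronal acetylcholine receptor; alpha3/beta4 (Homo sapiens), read by FLIPR; a lower number here means that less compound is needed, a higher number that more compound is needed for the effect. On these numbers compound 3 stands second highest of the three: its nearest neighbour is compound 2, whose value is within the usual scatter of it, so the two cannot be told apart; compound 1, the lowest of the three, lies well beyond the scatter from compound 3.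

The step under study goes from compound 3 to compound 4, `COc1cc(N2C[C@H]3CCNC[C@H]32)cnc1Br`. The difference is the two compounds have the same atoms and bonds and differ only in configuration as drawn: 2 of 2 stereo elements differ (all stereocentres are inverted: mirror images); a stereocentre at a saturated ring carbon is drawn S in compound 3 and R in compound 4; a stereocentre at a saturated ring carbon is drawn R in compound 3 and S in compound 4. Nothing leaves and nothing enters; the two compounds are mirror images of one another.

Going by the values given here, no pair of measured compounds here shares this kind of difference, so the size and direction of the step are not fixed by the data. Mirror-image pairs are often separated by a large gap, but which partner gives the lower number cannot be read from the three measured compounds. The estimate for compound 4 is therefore set near compound 3 with a wide range, an expected step of a 1.5-fold lower number from compound 3 to compound 4 (0.17 log units; within the scatter), giving an expected value for compound 4 of 2000 nM, between 250 nM and 15000 nM.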

Compound 4, half-maximal effective concentration: 202 nM
Compound 4: the middle estimate sits 9.9-fold (1.00 log units) above what was measured; measured number below the stated range.
By their numbers in this assay, from the lowest: compound 1; then compound 4; then compounds 3 and 2 (each within the scatter of the next).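

In this assay, inverting both stereocentres gives a 15-fold lower number from compound 3 to compound 4 (1.17 log units; beyond the scatter), so handedness alone moves the number well beyond the scatter, with compound 4 reaching 202 nM. No group can account for this gap, because nothing leaves or enters and only the arrangement in space changes: the fact that compounds 3 and 4 differ only in the configuration as drawn. The earlier compounds shown here could not show this, as no two of them differed in one place, whereas this pair gives a direct reading of how much the configuration matters for this substitution pattern and which mirror image gives the lower number.

As far as these compounds go, it remains open whether the configuration of compound 4 would still give the lower number, and by a similar margin, with other groups on the aromatic ring, such as a chlorine atom in place of the bromine or an ethoxy group in place of the methoxy. The mirror images of compound 1 and compound 2 are not among the compounds shown, so it is also open whether a gap of this size and direction holds for those structures.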